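A few compounds are considered here, and "the series" means these few. Any claim that something is new, unique, unknown or untested is made for them only; others in the source may bear on it.

In an ADME assay on BaF3 cells (Mus musculus) for cytotoxicity, read by MTT assay, with a stated time of 48 h (on this read-out lower numbers stand for stronger inhibition of growth and higher numbers for weaker inhibition of growth), compound 2 `CCCCCCCn1nc(-c2cc(C3CC3)on2)c2c(N)ncnc21` gives > 10000 nM, which is a limit of the assay and not a number. Compound 1 `Nc1ncnc2c1c(-c1cc(C3CC3)on1)nn2C1CCCCC1` gives > 10000 nM, also a limit. Compound 3 `CC(C)n1nc(/C=N/OCc2ccccc2)c2c(N)ncnc21` gives > 10000 nM, again a limit. Compound 2 therefore has no measured number to stand on, and the whole set comes down to the limit of > 10000 nM in this assay, at which 3 of the 3 values shown sit.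

Compound 4 `Nc1ncnc2c1c(-c1cc(C3CC3)on1)nn2C1CCOCC1` is not yet measured, and it changes one group of compound 2: oxan-4-yl in place of heptyl on an aromatic nitrogen. Oxan-4-yl replaces heptyl on an aromatic nitrogen, so an open chain gives way to a six-membered non-aromatic ring that carries a hydrogen-bond acceptor.

Going by the values given here, the only measured step at this place is a step that the two limits leave unreadable from compound 1 to compound 2, so no size can be carried over, and no step beyond the scatter in either direction is expected. The estimated change is a number no higher from compound 2 to compound 4 (the limit leaves the size open). The assay will most likely report only a limit again, and for compound 4 the expected value is 10000 nM, with an estimated range from 4000 nM to 25000 nM.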

Compound 4, concentration for 50% growth inhibition: > 10000 nM
Compound 4: only a limit was reported (the forecaster's own chance of this, stated with the estimate: 85%); the middle value sits exactly at the limit.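

Compound 1, compound 2 and compound 4 all give only a limit and not a number in this assay, so neither step to compound 4 can be read: the limit of > 10000 nM in this assay, at which 4 of the 4 values shown sit.

The compounds shown leave open which change, if any, would bring growth inhibition in this assay to a measurable number.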